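The compounds below may be only part of what the source reports. "The series", "measured", "known", "first", "only" and "open" are said of these compounds alone.

Compound 1, `COc1cc(C2=NNC(c3ccc(Cl)cc3)C2)ccc1O`, gives 80 nM in an assay on isolated protein for inhibition of Amine oxidase [flavin-containing] A (Homo sapiens), read by fluorescence and Amplex Red, with a stated time of 30 min; on this read-out higher numbers stand for weaker inhibition and lower numbers for stronger inhibition.
Compound 2, `COc1cc(C2=NN(C(=O)c3ccccc3)C(c3ccc(Cl)cc3)C2)ccc1O`, gives 26200 nM in this assay.
Compound 3, `COc1cc(C2=NN(S(=O)(=O)c3ccc(C)cc3)C(c3ccc(Cl)cc3)C2)ccc1O`, gives 40000 nM in this assay.

Compound 3 has the highest of the three numbers; its gap to compound 2 lies within the scatter, while compound 1 sits far lower. Compound 4 is `COc1cc(C2=NN(C(=S)Nc3ccccc3)C(c3ccc(Cl)cc3)C2)ccc1O`; it differs from compound 3 by a group of 9 heavy atoms (7 carbon, 1 nitrogen, 1 sulfur; one six-membered aromatic ring of carbon only) in place of a group of 10 heavy atoms (7 carbon, 2 oxygen, 1 sulfur; one six-membered aromatic ring of carbon only), on an amine nitrogen in a ring. For the measured compounds named here, the steps that bear on this are a 330-fold higher number from compound 1 to compound 2 (2.52 log units; beyond the scatter) and a 500-fold higher number from compound 1 to compound 3 (2.70 log units; beyond the scatter), both large, whereas a 1.5-fold higher number from compound 2 to compound 3 (0.18 log units; within the scatter) is within the scatter. Any group on that ring nitrogen so far has gone with a weak number, and the nature of the group has mattered little. Compound 4 carries such a group too, so no step beyond the scatter is expected, a 1.3-fold lower number from compound 3 to compound 4 (0.12 log units; within the scatter). Compound 4 is therefore estimated at 30000 nM in this assay, between 8000 nM and 100000 nM.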

Compound 4, inhibition constant: 19600 nM
Estimate against measurement, compound 4: 1.5-fold (0.18 log units) above; measured number inside the range.
By their numbers in this assay, from the lowest: compound 1; then compounds 4, 2 and 3 (each within the scatter of the next, the first and the last beyond it).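

A third kind of group on the amine nitrogen in the ring also goes with a weak number in this assay (a 250-fold higher number from compound 1 to compound 4 (2.39 log units; beyond the scatter)). The nature of the group now gives its first step beyond the scatter, though only a modest one (a 2.0-fold lower number from compound 3 to compound 4 (0.31 log units; beyond the scatter)), while the other comparison between substituted compounds stays within it (a 1.3-fold lower number from compound 2 to compound 4 (0.13 log units; within the scatter)). Nothing measured here explains these steps. Going by these compounds, whether a group as small as methyl or acetyl on that nitrogen would also go with so weak a number remains open. So does the effect of a longer chain ending in an amine.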